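This account rests on a few compounds, and the source may have more. Where it says the series, first, only, none or still open, it means among the compounds named here.

Working notes on the series. Compound 1 `COc1ccc(OC)c(/C=C/C(=O)/C=C/c2cc3ccccc3nc2Oc2ccc(Br)cc2)c1` serves as the starting point. In a functional assay on DU-145 cells (Homo sapiens) for cytotoxicity, read by MTT assay, with a stated time of 48 h (a higher number here means a weaker inhibitor, a lower number a stronger inhibitor), compound 1 gives only a limit, > 10000 nM. Compound 2 `COc1ccc(/C=C/C(=O)/C=C/c2cc3ccccc3nc2Oc2ccc(Br)cc2)cc1OC` carries 3,4-dimethoxyphenyl in place of 2,5-dimethoxyphenyl on a double-bonded chain carbon bound to a double-bonded chain carbon. In this assay compound 2 likewise gives only a limit, > 10000 nM. The step that the two limits leave unreadable from compound 1 to compound 2 is therefore not readable. Compound 3 `COc1ccc(OC)c(/C=C/C(=O)/C=C/c2cc3ccccc3nc2Oc2cccc(Cl)c2)c1` carries 3-chlorophenyl in place of 4-bromophenyl on an oxygen on an aromatic ring. In this assay compound 3 also gives only a limit, > 10000 nM. The step that the two limits leave unreadable from compound 1 to compound 3 is equally unreadable because of the limit of > 10000 nM in this assay, at which 3 of the 3 values shown sit. Compound 4 `COc1ccc(/C=C/C(=O)/C=C/c2cc3ccccc3nc2Oc2cccc(Cl)c2)cc1OC` has not yet been measured; it differs from compound 3 by 3,4-dimethoxyphenyl in place of 2,5-dimethoxyphenyl on a double-bonded chain carbon bound to a double-bonded chain carbon, the same change at the same place as that between compound 1 and compound 2. With the parent at the limit, the step is expected to remain unreadable as well, a step that the limit leaves unreadable from compound 3 to compound 4, resting on (the limit of > 10000 nM in this assay, at which 3 of the 3 values shown sit). Compound 4 is expected at 15000 nM, within 5000 nM to 50000 nM, and most likely again reported only as a limit.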

Compound 4, half-maximal inhibitory concentration: > 10000 nM
Compound 4: no number, only a limit (the forecaster's own chance of this, stated with the estimate: 80%); the middle value is on the limit's open side.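

No new step can be read for compound 4, either from compound 3 or from compound 2: the limit of > 10000 nM in this assay, at which 4 of the 4 values shown sit. The compounds shown leave open how either change affects potency, as none of them gives a number.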